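Benzothiophene amide on a bis-indole nitrile core

A few compounds are considered here, and "the series" means these few. Any claim that something is new, unique, unknown or untested is made for them only; others in the source may bear on it.

Four compounds share one core, differing only in the group on a saturated chain carbon. Compound 1 `CN1[C@@H]2c3[nH]c4ccccc4c3C[C@H]1[C@H](C#N)N1[C@@H](CN3C(=O)c4ccccc4C3=O)c3[nH]c4ccccc4c3C[C@@H]21` carries a phthalimide-type group and, in a functional assay on MCF7 cells (Homo sapiens) for cytotoxicity, read by MTT assay, with a stated time of 72 h (a higher number here means a weaker inhibitor, a lower number a stronger inhibitor), compound 1 gives 610 nM. Compound 2 `CN1[C@@H]2c3[nH]c4ccccc4c3C[C@H]1[C@H](C#N)N1[C@@H](CNC(=O)c3ccc(F)cc3)c3[nH]c4ccccc4c3C[C@@H]21`, with a 4-fluorophenyl amide, gives 980 nM, and a 1.6-fold higher number from compound 1 to compound 2 (0.21 log units; within the scatter). Compound 3 `CN1[C@@H]2c3[nH]c4ccccc4c3C[C@H]1[C@H](C#N)N1[C@@H](CNC(=O)c3cccc4c3CCCC4)c3[nH]c4ccccc4c3C[C@@H]21`, with a 1,2,3,4-tetrahydronaphthalen-5-yl amide, gives 4470 nM, the highest number of the three; a 4.6-fold higher number from compound 2 to compound 3 (0.66 log units; beyond the scatter). Compound 4 `CN1[C@@H]2c3[nH]c4ccccc4c3C[C@H]1[C@H](C#N)N1[C@@H](CNC(=O)c3cc4ccccc4s3)c3[nH]c4ccccc4c3C[C@@H]21` is the next variation: 1-benzothiophen-2-yl in place of 1,2,3,4-tetrahydronaphthalen-5-yl on a carbonyl carbon. For the measured compounds named here, no measured step matches this change. Going by the values given here, the one step that bears on it, the exchange of the aryl group on the amide carbonyl, a 4.6-fold higher number from compound 2 to compound 3 (0.66 log units; beyond the scatter), shows that such changes move the number modestly in either direction. A ring system of two aromatic rings sits between the two measured amides in shape, so compound 4 is expected to fall between compound 2 and compound 3, estimated at 2000 nM with a range of 700 nM to 6000 nM. The step of a 2.2-fold lower number from compound 3 to compound 4 (0.35 log units; beyond the scatter) is expected to be a modest decrease.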

Compound 4, half-maximal inhibitory concentration: 3180 nM
Compound 4: middle estimate off by 1.6-fold (0.20 log units), on the low side; measured number inside the range.
By their numbers in this assay, from the lowest: compounds 1 and 2 (each within the scatter of the next); then compounds 4 and 3 (each within the scatter of the next).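

In this assay, putting 1-benzothiophen-2-yl in place of 1,2,3,4-tetrahydronaphthalen-5-yl on the carbonyl carbon gives a 1.4-fold lower number from compound 3 to compound 4 (0.15 log units; within the scatter), so the assay does not separate these two groups of two rings. Both amides stand apart from the single-ring 4-fluorophenyl amide, now confirmed by a 3.2-fold higher number from compound 2 to compound 4 (0.51 log units; beyond the scatter) and matched by a 5.2-fold higher number from compound 1 to compound 4 (0.72 log units; beyond the scatter), which suggests that two rings on this carbonyl carbon go with higher numbers, though this rests on compound 2 alone as the single-ring example, and compound 1, with its own two rings in a phthalimide-type group, goes against it. Nothing measured here gives a cause for these differences.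

As far as these compounds go, it remains open whether plain phenyl or a pyridine ring on the carbonyl carbon would give a number like that of compound 2. The part played by the fluorine itself also stays unresolved.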